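Phenol for methoxy on the aryl ring: cytotoxicity outlook

The source may hold more compounds than are shown below. What is called first, only, known or untested is meant among the compounds shown, and "the series" means these compounds.

Compound 1, `Cc1cc(I)cn2c(CSCCc3ccccc3)cnc12`, gives in an ADME assay on HEL cells (Homo sapiens) for cytotoxicity, with a stated time of 3 days (a lower number here means that less compound is tolerated, a higher number that more compound is tolerated), only a limit, >= 0.8 ug/mL.
Compound 2, `Cc1cc(-c2ccccc2)cn2c(CSCCc3ccccc3)cnc12`, gives 20 ug/mL.
Compound 3, `COc1ccc(-c2cc(C)c3ncc(CSCCc4ccccc4)n3c2)cc1`, gives 20 ug/mL.

Compound 3 stands level with compound 2: the step of no change at the digits printed from compound 2 to compound 3 (within the scatter) stays within the scatter. Since the value of compound 1 is a limit, the steps a step that the limit leaves unreadable from compound 1 to compound 2 and a step that the limit leaves unreadable from compound 1 to compound 3 cannot be read. Compound 4, `Cc1cc(-c2cccc(O)c2)cn2c(CSCCc3ccccc3)cnc12`, differs from compound 3 by 3-hydroxyphenyl in place of 4-methoxyphenyl on an aromatic carbon. Among the measured compounds shown here, the only readable step touching this aryl substituent, no change at the digits printed from compound 2 to compound 3 (within the scatter), shows no change, so no movement beyond the scatter is expected here either, though a single step is thin evidence. Compound 4 is therefore estimated at 20 ug/mL, within 8 ug/mL to 50 ug/mL, an expected step of no change at the digits printed from compound 3 to compound 4 (within the scatter).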

Compound 4, minimum cytotoxic concentration: 20 ug/mL
Compound 4: the middle estimate sits on the measured number at the digits printed; the range from low to high includes it.
By their numbers in this assay, from the lowest: compounds 2, 3 and 4 (each within the scatter of the next).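

In this assay, 3-hydroxyphenyl in place of 4-methoxyphenyl brings no change at the digits printed from compound 3 to compound 4 (within the scatter), and hydroxy in place of hydrogen on the aryl ring brings no change at the digits printed from compound 2 to compound 4 (within the scatter). This position therefore carries an aryl group with a hydrogen-bond donor, as well as the two without one, with no step beyond the scatter. The step from compound 1 to compound 4 cannot be read, since compound 1 gives only a limit: the limit of >= 0.8 ug/mL in this assay, at which 1 of the 4 values shown sits.

From the compounds shown here alone, whether an amine or a carboxylic acid on this aryl ring would stay level with compounds 2, 3 and 4 remains open.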